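The compounds below may be only part of what the source reports. "The series", "measured", "known", "first", "only" and "open" are said of these compounds alone.

Measured compounds:
compound 1 `Cc1ccc2c(=O)c(CSC(=S)N3CCCCC3)coc2c1` — > 25000 nM
compound 2 `O=c1c(CSC(=S)N2CCCC2)coc2ccccc12` — > 25000 nM
compound 3 `CN1CCN(C(=S)SCc2coc3ccccc3c2=O)CC1` — 5900 nM

In a functional assay on HeLa cells (Homo sapiens) for antiproliferative activity, read by MTT assay, with a stated time of 72 h (a higher number here means a weaker inhibitor, a lower number a stronger inhibitor), compound 2 gives > 25000 nM, which is a limit of the assay and not a number. Compound 1 also gives > 25000 nM in this assay, again a limit. For the measured compounds named here, compound 3 gives 5900 nM, the only actual number among the three, and the change from the pyrrolidine ring to the methylpiperazine gives an at least 4.2-fold lower number from compound 2 to compound 3 (0.62 log units; beyond the scatter). Two of the three values thus sit at the limit of > 25000 nM in this assay, at which 2 of the 3 values shown sit.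

The next compound, compound 4 `Cc1ccc2c(=O)c(CSC(=S)N3CCCC3)coc2c1`, keeps the pyrrolidine amide of compound 2 and changes only the core: methyl in place of hydrogen on an aromatic carbon. Going by the values given here, none of the measured steps involves this kind of change; the one step on record concerns the amine ring, not the aromatic ring. Compound 1, which also carries a methyl but a different amine ring, stands at the limit just as compound 2 does. Among the compounds with values here, with a limit as the starting point and no step that shows a methyl moving the number, a step that the limit leaves unreadable from compound 2 to compound 4 is expected in this assay, meaning no change beyond the scatter. Compound 4 is therefore estimated at 30000 nM, with a range of 12000 nM to 80000 nM, most likely reported again as a limit.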

Compound 4, half-maximal inhibitory concentration: 4400 nM
Estimate against measurement, compound 4: 6.8-fold (0.83 log units) above; measured number outside the range, below it.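

In this assay, a methyl in place of hydrogen on an aromatic carbon of the shared core proves able to move the number on its own: the change gives an at least 5.6-fold lower number from compound 2 to compound 4 (0.75 log units; beyond the scatter). Until now only the amine ring had been seen to matter, so this carbon of the six-membered aromatic ring is a second place where one small change counts. The methyl is not enough by itself, however, since with the methyl kept, pyrrolidin-1-yl in place of piperidin-1-yl gives an at least 5.6-fold lower number from compound 1 to compound 4 (0.75 log units; beyond the scatter), which means the outcome here depends on the methyl and the amine ring together.

As far as these compounds go, the full size of both steps stays open, as each one starts from a value that is a limit and not a number: the limit of > 25000 nM in this assay, at which 2 of the 4 values shown sit. Also open is whether the same methyl would lower the number further on the 4-methylpiperazin-1-yl compound 3, and whether a different group on this carbon, such as a chlorine atom, a methoxy group or an ethyl chain, would act as the methyl does.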